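The source may report more compounds than this note shows. Statements on the series, on what has been measured and on what is new or still open speak of the compounds shown alone.

Of the compounds shown here, two have numbers so far in a physicochemical assay for solubility, at pH 7.4 (a lower number here means a less soluble compound, a higher number a more soluble compound), and they cannot be told apart. Compound 1 (`O=c1cc(-c2ccccc2)nc(-n2cccn2)[nH]1`) gives 190000 nM and compound 2 (`Cc1cc(C2CC2)n(-c2nc(C(F)(F)F)cc(=O)[nH]2)n1`) gives 160000 nM in the same measurement, so compound 2 stands within the usual scatter of compound 1. Compound 3 (`Cc1cc(NCCO)n(-c2nc(C(F)(F)F)cc(=O)[nH]2)n1`) has not yet been measured. It carries (2-hydroxyethyl)amino in place of the cyclopropyl of compound 2, on an aromatic carbon of a five-membered aromatic ring with 2 nitrogen ((2-hydroxyethyl)amino in place of cyclopropyl on an aromatic carbon). Among the compounds with values here, no measured pair differing in one place is available, so the data do not show directly what such an exchange does. Within the data shown here, the only guide is that compound 1 and compound 2 differ in more than one place and still lie within the scatter of each other. On that basis, no step beyond the scatter is expected. The estimated change is small (a 1.2-fold higher number from compound 2 to compound 3 (0.07 log units; within the scatter)). For compound 3 the expected value is 190000 nM and the estimated range runs from 100000 nM to 300000 nM until the measurement is in.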

Compound 3, solubility: 200000 nM
Estimate against measurement, compound 3: 1.1-fold (0.02 log units) below; the measured number falls inside the stated range.
By their numbers in this assay, from the lowest: compounds 2, 1 and 3 (each within the scatter of the next).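

Within the data shown here, compound 2 and compound 3 form the first pair that differs in only one place, so the effect of an exchange on an aromatic carbon of a five-membered aromatic ring with 2 nitrogen can now be read directly, rather than inferred from compounds that differ in several places. In this assay, among these compounds, replacing cyclopropyl, a three-membered non-aromatic ring of carbon only with 0 hydrogen-bond donors and 0 hydrogen-bond acceptors, with the open-chain (2-hydroxyethyl)amino, which has 2 hydrogen-bond donors and 2 hydrogen-bond acceptors, gives a 1.3-fold higher number from compound 2 to compound 3 (0.10 log units; within the scatter), so even this exchange of ring for chain produces no step that can be told from the scatter at this position. No measurement shown here accounts for that outcome.

As far as these compounds go, whether a carboxylic acid or a longer chain at this position would give a step beyond the scatter remains open. A single pair also leaves open whether the same exchange would give a similar step on the core of compound 1, which differs from compound 2 in more than one place.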